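This account rests on a few compounds, and the source may have more. Where it says the series, first, only, none or still open, it means among the compounds named here.

Working notes on the step to compound 4. In a functional assay on CaEs17 cells (Homo sapiens) for cytotoxicity, read by MTT assay, with a stated time of 72 h (on this read-out higher numbers stand for weaker inhibition and lower numbers for stronger inhibition), compound 1 `C=C1C(=O)[C@@]23C(=O)OC[C@]4(C(=O)CCC(C)(C)[C@H]4C=O)[C@@H]2CC[C@@H]1[C@H]3OC(=O)c1ccccc1` gives 1710 nM, compound 2 `C=C1C(=O)[C@@]23C(=O)OC[C@]4(C(=O)CCC(C)(C)[C@H]4C=O)[C@@H]2CC[C@@H]1[C@H]3OC(=O)c1ccc(C)cc1` gives 1050 nM and compound 3 `C=C1C(=O)[C@@]23C(=O)OC[C@]4(C(=O)CCC(C)(C)[C@H]4C=O)[C@@H]2CC[C@@H]1[C@H]3OC(=O)c1ccc([N+](=O)[O-])cc1` gives 2680 nM. The number for compound 1 thus lies inside the span of the other two and within the scatter of each. Only one measured gap passes the scatter, and it is modest: a 2.6-fold higher number from compound 2 to compound 3 (0.41 log units; beyond the scatter).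

Compound 4 `C=C1C(=O)[C@@]23C(=O)OC[C@]4(C(=O)CCC(C)(C)[C@H]4C=O)[C@@H]2CC[C@@H]1[C@H]3OC(=O)c1ccccc1F` keeps the core of compound 1 and differs by fluoro in place of hydrogen on an aromatic carbon, ortho to a large group, so that phenyl becomes 2-fluorophenyl.

Within the data shown here, two measured steps bear on this change, as both replace a hydrogen on the same aromatic ring. Methyl gave a 1.6-fold lower number from compound 1 to compound 2 (0.21 log units; within the scatter) and nitro gave a 1.6-fold higher number from compound 1 to compound 3 (0.20 log units; within the scatter). Among the measured compounds shown here, neither compound 2 nor compound 3 carries its group ortho to a large group, so these steps are only an indirect guide, and the data hold no measured fluoro compound. On that basis, no step beyond the scatter is expected in this assay, and no direction is favoured. The estimated step is a 1.0-fold lower number from compound 1 to compound 4 (0.00 log units; within the scatter). The expected value for compound 4 is 1700 nM, with an estimated range of 900 nM to 3200 nM.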

Compound 4, half-maximal inhibitory concentration: 8550 nM
Beside the measured number, compound 4's estimate is 5.0-fold (0.70 log units) below it, outside the stated range (above it).
By their numbers in this assay, from the lowest: compounds 2, 1 and 3 (each within the scatter of the next, the first and the last beyond it); then compound 4.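

In this assay, among these compounds, the change from phenyl to 2-fluorophenyl is the first single substitution on this ring to pass the scatter from the parent, a 5.0-fold higher number from compound 1 to compound 4 (0.70 log units; beyond the scatter), whereas the methyl and nitro steps from compound 1 stay within it. The number for compound 4 also stands clear of both other compounds, with a 3.2-fold higher number from compound 3 to compound 4 (0.50 log units; beyond the scatter) and an 8.1-fold higher number from compound 2 to compound 4 (0.91 log units; beyond the scatter), so one fluoro ortho to a large group places this compound outside the span set by compounds 2 and 3, on the side of the higher numbers. Nothing at hand accounts for this step.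

It remains open whether the higher number goes with fluoro itself or with the place ortho to a large group, as the methyl of compound 2 and the nitro of compound 3 do not stand at that place, and fluoro stands nowhere else among these compounds. Also open, from the compounds shown here alone, is how the same read-out would respond to a chloro, a methoxy, an amine or a carboxylic acid ortho to a large group on this ring.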